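Swapping methylsulfanyl for benzylselanyl on the quinoline amidine core

This account rests on a few compounds, and the source may have more. Where it says the series, first, only, none or still open, it means among the compounds named here.

Compound 1 `O=C(/N=C(/NC(=O)c1ccno1)[Se]Cc1ccccc1)c1ccno1` gives 57300 nM in a functional assay on K562 cells (Homo sapiens) for cytotoxicity, read by MTT assay, with a stated time of 72 h; a lower number here means a stronger inhibitor of growth, a higher number a weaker inhibitor of growth. Compound 2 `C[Se]/C(=N\C(=O)c1cnc2ccccc2c1)NC(=O)c1cnc2ccccc2c1`, which carries the quinoline-type core shared with the remaining compounds, gives 29900 nM in this assay. Within the data shown here, compound 3 `CS/C(=N\C(=O)c1cnc2ccccc2c1)NC(=O)c1cnc2ccccc2c1` reaches only the limit of this assay, > 100000 nM, so no number is known for it; it is the one value sitting at the limit of > 100000 nM in this assay, at which 1 of the 3 values shown sits. Among the measured compounds shown here, the single measured step, an at least 3.3-fold higher number from compound 2 to compound 3 (0.52 log units; beyond the scatter), shows that replacing selenium by sulfur on that carbon weakened growth inhibition. Compound 4 `O=C(/N=C(/NC(=O)c1cnc2ccccc2c1)[Se]Cc1ccccc1)c1cnc2ccccc2c1` differs from compound 3 by a group of 8 heavy atoms (7 carbon, 1 selenium; one six-membered aromatic ring of carbon only) in place of a group of 2 heavy atoms (1 carbon, 1 sulfur; no ring), on a carbon with a double bond to nitrogen. This change restores selenium at the same carbon, the reverse of the measured step, and compound 1 shows that a benzylselanyl group on a different core still gives a measurable number, 57300 nM. A move back toward the region of compound 2, roughly reversing an at least 3.3-fold higher number from compound 2 to compound 3 (0.52 log units; beyond the scatter), is therefore expected. Compound 4 is estimated at 40000 nM, within 15000 nM to 110000 nM, a step of an at least 2.5-fold lower number from compound 3 to compound 4 (0.39 log units; beyond the scatter).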

Compound 4, concentration for total growth inhibition: 72600 nM
The estimate for compound 4 lay 1.8-fold (0.26 log units) below the measured number, within the range that was stated.
By their numbers in this assay, from the lowest: compounds 2, 1 and 4 (each within the scatter of the next, the first and the last beyond it). At a limit, above all of these: compound 3.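

In this assay, the result separates two parts of the change at this carbon with a double bond to nitrogen. On the shared core, phenyl in place of hydrogen on the saturated chain carbon bound to selenium gives a 2.4-fold higher number from compound 2 to compound 4 (0.39 log units; beyond the scatter), so adding the ring to the selenium-bound chain weakens growth inhibition. The comparison with the sulfur compound is less firm, at an at least 1.3-fold lower number from compound 3 to compound 4 (0.13 log units; that floor lies within the scatter), and that floor does not establish a gain beyond the scatter. Compound 3 remains a limit and not a number: the limit of > 100000 nM in this assay, at which 1 of the 4 values shown sits.

The compounds shown leave open how much of the difference between compound 3 and compound 4 belongs to selenium and how much to the phenyl, since benzylsulfanyl does not appear among them. They also leave open how an ethyl chain on selenium or an amine on this carbon would behave.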